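The compounds below may be only part of what the source reports. "The series", "measured", "known", "first", "only" and "open" are said of these compounds alone.

The measured compounds:

Compound 1, `O=C(O)CCC(=O)Nc1ccc(-c2nc3cc(C(F)(F)F)ccc3[nH]2)cc1`, gives > 100000 nM in an ADME assay on MDBK cells (Bos taurus) for cytotoxicity, read by MTT assay, with a stated time of 96 h; on this read-out lower numbers stand for higher toxicity in this test and higher numbers for lower toxicity in this test; this is a limit of the test, not a number.
Compound 2, `CCC(=O)Nc1ccc(-c2nc3cc(C(F)(F)F)ccc3[nH]2)cc1`, gives > 100000 nM in this assay; this too is a limit of the test, not a number.
Compound 3, `Cn1c(-c2ccc(NC(=O)CN3CCCCC3)cc2)nc2cc(C(F)(F)F)ccc21`, gives 100000 nM in this assay.

Within the data shown here, compound 3 thus stands as the only compound with a real number; the other two values are limits, as summed up by the limit of > 100000 nM in this assay, at which 2 of the 3 values shown sit. Among the measured compounds shown here, the one step between measured compounds, a step that the two limits leave unreadable from compound 1 to compound 2, has no readable size, since both of its ends are limits and it concerns a different part of the molecule.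

Compound 4, `O=C(CN1CCCCC1)Nc1ccc(-c2nc3cc(C(F)(F)F)ccc3[nH]2)cc1`, differs from compound 3 by hydrogen in place of methyl on an aromatic nitrogen. For the measured compounds named here, no measured step touches this position, so nothing in the data points to a change beyond the usual scatter, and the step of no change at the digits printed from compound 3 to compound 4 (within the scatter) is expected to be small. Compound 4 is therefore estimated at 100000 nM, with a range from 50000 nM to 200000 nM, and a fair chance that only a limit is reported, as for compound 1 and compound 2.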

Compound 4, half-maximal cytotoxic concentration: 6000 nM
Compound 4: the middle estimate sits 17-fold (1.22 log units) above what was measured; measured number below the stated range.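

Among these compounds, the aromatic nitrogen turns out to matter, which no earlier step could show: in this assay there is a 17-fold lower number from compound 3 to compound 4 (1.22 log units; beyond the scatter), so one methyl swapped for hydrogen here moves the result well beyond the scatter, towards higher toxicity in this test. With hydrogen on that nitrogen, the group on the chain carbon also counts, with an at least 16-fold lower number from compound 2 to compound 4 (1.22 log units; beyond the scatter) and an at least 16-fold lower number from compound 1 to compound 4 (1.22 log units; beyond the scatter). Both of these steps start from a limit, so they give only a minimum size: the limit of > 100000 nM in this assay, at which 2 of the 4 values shown sit.

As far as these compounds go, it remains open whether ethyl on the aromatic nitrogen would behave like methyl or like hydrogen. From the compounds shown here alone, it is also open whether the piperidin-1-yl group itself is needed, or whether a smaller amine such as dimethylamino on the same chain carbon would give a similar number.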